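From propyl to cyclopentyl on the shared core

The source may hold more compounds than are shown below. What is called first, only, known or untested is meant among the compounds shown, and "the series" means these compounds.

Three measured compounds share the core of compound 1 `COc1cc2nc(C3CCC3)nc(N3CCN(c4ccccn4)CC3)c2cc1OC`, and in an in vitro assay on U2OS cells for agonist activity at neurotensin receptor type 2 (Homo sapiens), read by reporter gene assay and beta-arrestin recruitment (on this read-out higher numbers stand for an effect only at larger amounts of compound and lower numbers for an effect already at smaller amounts), compound 1 gives > 80000 nM, a limit of the assay rather than a number. Compound 2 `COc1cc2ncnc(N3CCN(c4ccccc4OC)CC3)c2cc1OC` gives > 80000 nM in this assay, again only a limit. Compound 3 `CCCc1nc(N2CCN(c3ccccc3OC)CC2)c2cc(OC)c(OC)cc2n1` stands at the same place: in this assay compound 3 gives > 80000 nM, which is a limit and not a number. Going by the values given here, every value shown sits at this boundary (the limit of > 80000 nM in this assay, at which 3 of the 3 values shown sit), and the single step that joins two measured compounds, a step that the two limits leave unreadable from compound 2 to compound 3, has no readable size because both of its ends are limits.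

Compound 4 `COc1cc2nc(C3CCCC3)nc(N3CCN(c4ccccc4OC)CC3)c2cc1OC` differs from compound 3 in one place: cyclopentyl in place of propyl on an aromatic carbon. Among the compounds with values here, no measured step speaks to this change with a readable size, since the only comparison at hand is a step that the two limits leave unreadable from compound 2 to compound 3 and it leaves the matter open. Compound 3 is therefore the sole anchor, and compound 4 is expected to remain where it stands, most likely as a limit once more. The estimated step that the limit leaves unreadable from compound 3 to compound 4 is not expected to exceed the scatter. In this assay compound 4 is estimated at 100000 nM, within 40000 nM to 300000 nM.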

Compound 4, half-maximal effective concentration: > 80000 nM
Compound 4: only a limit was reported; the forecaster's own chance of this, stated with the estimate: 85%; the middle value does not contradict the limit.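

Neither compound 2 nor compound 3 gives a readable step to compound 4, because each comparison joins two limits of the assay: the limit of > 80000 nM in this assay, at which 4 of the 4 values shown sit.

The compounds shown leave open whether any group at this place on the shared core would give a readable value in this assay.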